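This account rests on a few compounds, and the source may have more. Where it says the series, first, only, none or still open, it means among the compounds named here.

Three compounds have been measured in a functional assay on MDA-MB-231 cells (Homo sapiens) for antiproliferative activity, read by MTT assay, with a stated time of 48 h; on this read-out lower numbers stand for stronger inhibition and higher numbers for weaker inhibition:

compound 1 `COC(=O)/C(=C/c1ccccc1)CN1C(=O)[C@@H](OC)[C@H]1c1ccc(F)cc1`: 21800 nM
compound 2 `COc1ccc(OC)c([C@@H]2[C@H](OC)C(=O)N2C/C(C#N)=C/c2ccccc2)c1`: 23400 nM
compound 3 `CO[C@@H]1C(=O)N(C/C(C#N)=C/c2ccccc2)[C@@H]1c1ccc(Cl)cc1Cl`: 17000 nM

The value of compound 1 lies within the usual scatter of the values of both compound 2 and compound 3, so these three cannot be ranked in this assay.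

Compound 4 `COC(=O)/C(=C/c1ccccc1)CN1C(=O)[C@@H](OC)[C@H]1c1cccc([N+](=O)[O-])c1`, not yet measured, keeps the rest of compound 1 but carries 3-nitrophenyl in place of 4-fluorophenyl on a saturated ring carbon, next to the ring nitrogen: 3-nitrophenyl in place of 4-fluorophenyl on a saturated ring carbon.

Among the compounds with values here, no measured pair isolates this change, so the data offer no direct guide to its size. Within the data shown here, the only indirect evidence comes from the other two compounds. Compound 2 at 23400 nM and compound 3 at 17000 nM carry other substituted phenyl groups on that ring carbon, and a nitrile in place of the ester of compound 1, yet both values stay within the scatter of the value of compound 1. With that evidence, no change beyond the scatter is expected. The expected step is a 1.1-fold lower number from compound 1 to compound 4 (0.04 log units; within the scatter), estimated to stay within the scatter, with no firm direction. Compound 4 is expected at 20000 nM, with an estimated range from 7000 nM to 50000 nM.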

Compound 4, half-maximal inhibitory concentration: 14400 nM
For compound 4 the middle estimate is 1.4-fold (0.14 log units) above the measured one; the range from low to high includes it.
By their numbers in this assay, from the lowest: compounds 4, 3, 1 and 2 (each within the scatter of the next).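

In this assay, replacing 4-fluorophenyl with 3-nitrophenyl on a saturated ring carbon, next to the ring nitrogen, gives a 1.5-fold lower number from compound 1 to compound 4 (0.18 log units; within the scatter) while the ester and the rest of the core of compound 1 stay in place. This pair isolates one change at this position, which compound 2 and compound 3 could not do, as each also carries a nitrile in place of the ester, and it shows that the added heavy atoms and hydrogen-bond acceptors counted for 3-nitrophenyl, together with the different placement of the substituent on the phenyl ring, leave the number within the scatter. No accompanying measurement bears on this result, so the data say only how large the step is and nothing about what lies behind it.

As far as these compounds go, it remains open whether this position would still stay within the scatter if the substituted phenyl gave way to something other than a benzene ring, such as a pyridine ring or a simple alkyl chain. Equally open, from the compounds shown here alone, is how an amine or a carboxylic acid on that phenyl ring would read in this assay with the ester of compound 1 kept.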